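From 3,4-dimethoxyphenyl to 3,4-dihydroxyphenyl in compound 4

The compounds below may be only part of what the source reports. "The series", "measured", "known", "first", "only" and "open" are said of these compounds alone.

Measured in a functional assay on HL-60 cells (Homo sapiens) for inhibition, read by CCK-8 assay, with a stated time of 48 h; a higher number here means a weaker inhibitor, a lower number a stronger inhibitor:
Compound 1 `COc1ccc(Oc2ccc(C(C)C)cc2-c2ccsc2S(=O)(=O)NCCNC(=S)Nc2ccc([N+](=O)[O-])cc2)cc1OC`: 11200 nM
Compound 2 `COc1ccc(Oc2ccc(C(C)C)cc2-c2ccsc2S(=O)(=O)NCCNC(=O)Nc2cc(Cl)cc(Cl)c2)cc1OC`: 6500 nM
Compound 3 `O=S(=O)(NCCNC(=S)Nc1cccc(Cl)c1)c1ccc(-c2ccccc2OCc2ccccc2)s1`: > 50000 nM, a limit of the assay

Among the compounds with values here, compound 2 stands at 6500 nM, one of only two true numbers in this assay. Within the data shown here, the single measured step, a 1.7-fold lower number from compound 1 to compound 2 (0.24 log units; within the scatter), leaves it level with compound 1. Compound 3 gives only a limit, > 50000 nM.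

Compound 4 `CC(C)c1ccc(Oc2ccc(O)c(O)c2)c(-c2ccsc2S(=O)(=O)NCCNC(=O)Nc2cc(Cl)cc(Cl)c2)c1` carries 3,4-dihydroxyphenyl in place of 3,4-dimethoxyphenyl on an oxygen on an aromatic ring. Among the measured compounds shown here, the one measured step changes a different place, on an amine nitrogen, so no measurement speaks directly to this change. With nothing to set a direction, the expectation in this assay stays close to compound 2 at 6500 nM, with no shift beyond the scatter. The expected change is a 1.3-fold lower number from compound 2 to compound 4 (0.11 log units; within the scatter). Compound 4 is estimated at 5000 nM, with an expected range of 1500 nM to 18000 nM.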

Compound 4, half-maximal inhibitory concentration: 6500 nM
Compound 4: middle estimate off by 1.3-fold (0.11 log units), on the low side; the range from low to high includes it.
By their numbers in this assay, from the lowest: compounds 2, 4 and 1 (each within the scatter of the next). At a limit, above all of these: compound 3.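

In this assay, replacing 3,4-dimethoxyphenyl with 3,4-dihydroxyphenyl on the oxygen on an aromatic ring gives no change at the digits printed from compound 2 to compound 4 (within the scatter). Within the data shown here, the earlier step changed only the group on an amine nitrogen, so this is the first reading at this position, and it shows that hydrogen-bond donors can enter here with the number staying within the scatter. Nothing measured here offers a reason for this outcome.

On these data alone, whether a carboxylic acid or an amine on this ring, or a longer chain on this oxygen in place of the ring, would move the number in this assay remains open. As far as these compounds go, it is also open whether the same change would read alike with the group that compound 1 carries on the amine nitrogen.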